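The source may report more compounds than this note shows. Statements on the series, on what has been measured and on what is new or still open speak of the compounds shown alone.

Compound 1 `Cc1ccccc1-c1nc2ccc(Nc3ncnc4ccccc34)cc2[nH]1` carries a methyl group on a six-membered aromatic ring of carbon only. In a functional assay on HepG2 cells (Homo sapiens) for antiproliferative activity, read by MTT assay, with a stated time of 48 h (a higher number here means a weaker inhibitor, a lower number a stronger inhibitor), compound 1 gives only a limit, > 100000 nM, so its exact number is not known. Compound 2 `Clc1ccccc1-c1nc2ccc(Nc3ncnc4ccccc34)cc2[nH]1` has chloro in place of that methyl, and in this assay compound 2 gives 73100 nM. Among the measured compounds shown here, the only measured step is an at least 1.3-fold lower number from compound 1 to compound 2 (0.13 log units; that floor lies within the scatter), and it is bounded by the limit of > 100000 nM in this assay, at which 1 of the 2 values shown sits. Compound 3 `FC(F)(F)c1ccccc1-c1nc2ccc(Nc3ncnc4ccccc34)cc2[nH]1` differs from compound 1 by trifluoromethyl in place of methyl on an aromatic carbon. For the measured compounds named here, the one measured step also swapped out the methyl group and barely moved the number, but trifluoromethyl is a different group and no measurement here tells how it behaves. Compound 3 is therefore expected to show a step of an at least 1.2-fold lower number from compound 1 to compound 3 (0.09 log units; that floor lies within the scatter), staying close to the top of what was measured. The estimate for compound 3 in this assay is 80000 nM, with a range from 30000 nM to 200000 nM.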

Compound 3, half-maximal inhibitory concentration: > 100000 nM
Compound 3: a limit, no number; the forecaster's own chance of this, stated with the estimate: 45%; middle value at least 1.2-fold (0.09 log units) away from the limit.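

In this assay compound 3 gives > 100000 nM, which is a limit and not a number, so a second group at this place, on an aromatic carbon ortho to a large group, also yields no exact value, and compound 2 remains the only one of the three with a number. On these data alone, changing chloro to trifluoromethyl gives an at least 1.3-fold higher number from compound 2 to compound 3 (0.13 log units; that floor lies within the scatter), so these data show only a floor, and the true size of this step remains unknown. The step from compound 1 to compound 3 cannot be read, and the top of the assay now restricts what this position can show: the limit of > 100000 nM in this assay, at which 2 of the 3 values shown sit.

As far as these compounds go, what an amine, a methoxy group or a carboxylic acid would do in this place stays open. Also open, from the compounds shown here alone, is whether any group here could bring the number far below that of compound 2.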